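Fluoromethyl in place of methyl on compound 1

This account rests on a few compounds, and the source may have more. Where it says the series, first, only, none or still open, it means among the compounds named here.

Compound 1 `Cc1cc(CCCOc2c(C)cc(-c3noc(C)n3)cc2C)on1` gives 0.45 h
Compound 2 `CCc1cc(CCCOc2c(C)cc(-c3noc(C)n3)cc2C)on1` gives 0.183 h
Compound 3 `COCc1cc(CCCOc2c(C)cc(-c3noc(C)n3)cc2C)on1` gives 0.5 h

In an in vitro ADME assay on microsomes from liver (Simiiformes) (a higher number here means that the compound lasts longer, a lower number that the compound disappears faster), compound 1 shares the upper end of the three numbers with compound 3 and stands clear of compound 2 alone. Methoxy in place of hydrogen gave a 1.1-fold higher number from compound 1 to compound 3 (0.05 log units; within the scatter) and methyl in place of hydrogen gave a 2.5-fold lower number from compound 1 to compound 2 (0.39 log units; beyond the scatter) while methoxy in place of methyl gave a 2.7-fold higher number from compound 2 to compound 3 (0.44 log units; beyond the scatter) on the same carbon.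

The next compound is compound 4 `Cc1cc(CCCOc2c(C)cc(-c3noc(CF)n3)cc2C)on1` which differs from compound 1 by fluoro in place of hydrogen on a saturated chain carbon bound to an aromatic carbon so that methyl becomes fluoromethyl. The three measured steps fall on the same kind of place, a saturated chain carbon bound to an aromatic carbon, but on a different methyl group from the one in 5-methyl-1,2,4-oxadiazol-3-yl. Going by the values given here, no fluoro step has been measured, so they offer only loose guidance. The expected change is a 1.1-fold lower number from compound 1 to compound 4 (0.05 log units; within the scatter) and thus none beyond the scatter in this assay as far as can be estimated. For compound 4 the estimate is 0.4 h with an expected range of 0.18 h to 0.8 h in this measurement.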

Compound 4, half-life: 0.233 h
Compound 4: the middle estimate sits 1.7-fold (0.23 log units) above what was measured; the range from low to high includes it.
By their numbers in this assay, from the lowest: compounds 2, 4, 1 and 3 (each within the scatter of the next, the first and the last beyond it).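

Going by these compounds alone, compound 4 gives the first reading at the methyl group of 5-methyl-1,2,4-oxadiazol-3-yl, as all earlier steps fell on the other methyl group of the shared core. In this assay, fluoro in place of hydrogen gives a 1.9-fold lower number from compound 1 to compound 4 (0.29 log units; within the scatter), so this single fluorine on a saturated chain carbon bound to an aromatic carbon does not separate the two compounds beyond the usual scatter. Nothing available accounts for the size of this step or links it to any property of the fluoromethyl group.

The compounds shown leave open whether difluoromethyl or trifluoromethyl at this place would stay within the scatter of compound 1. They also leave open whether ethyl or methoxymethyl here would repeat the steps seen on the other methyl group.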